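This account rests on a few compounds, and the source may have more. Where it says the series, first, only, none or still open, it means among the compounds named here.

Values in a functional assay on K562 cells (Homo sapiens) for antiproliferative activity, with a stated time of 72 h; on this read-out higher numbers stand for weaker inhibition and lower numbers for stronger inhibition:
compound 1 `OC[C@H]1O[C@@H](n2cnc3c(NCc4ccc(Cl)c(Cl)c4)ncnc32)[C@H](O)[C@@H]1O`: 10800 nM
compound 2 `OC[C@H]1O[C@@H](n2cnc3c(NCc4ccc(F)c(F)c4F)ncnc32)[C@H](O)[C@@H]1O`: > 166000 nM, a limit of the assay, not a number

Compound 2 stands only at the limit of > 166000 nM in this assay, at which 1 of the 2 values shown sits, so its place among the numbers is a bound and nothing more. Within the data shown here, the one measured step is an at least 15-fold higher number from compound 1 to compound 2 (1.18 log units; beyond the scatter), which shows that exchanging the substituents on the phenyl attached to the saturated chain carbon can move this read-out far beyond the scatter.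

Compound 3 `OC[C@H]1O[C@@H](n2cnc3c(NCc4cccc(C(F)(F)F)c4)ncnc32)[C@H](O)[C@@H]1O` is not yet measured. Its change is 3-(trifluoromethyl)phenyl in place of 2,3,4-trifluorophenyl on a saturated chain carbon bound to a nitrogen on an aromatic ring. This step is not the reverse of the measured one, so the measured step serves only as a gauge of how much this phenyl tolerates. Compound 1 with its two-substituent ring gave 10800 nM. A return from the limit toward that region is expected for compound 3, with the expected step of an at least 4.1-fold lower number from compound 2 to compound 3 (0.61 log units; beyond the scatter). Compound 3 is therefore estimated at 40000 nM, within 8000 nM to 166000 nM.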

Compound 3, half-maximal inhibitory concentration: > 166000 nM
Compound 3: a limit, no number; the forecaster's own chance of this, stated with the estimate: 30%; at least 4.1-fold (0.61 log units) between middle value and limit.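

In this assay, 3-(trifluoromethyl)phenyl in place of 3,4-dichlorophenyl on the saturated chain carbon gives an at least 15-fold higher number from compound 1 to compound 3 (1.18 log units; beyond the scatter). The step from compound 2 to compound 3 cannot be read, as neither compound has a number, only a limit of the assay. Two different fluorine-bearing phenyl groups at this place now end at the same limit, so the result seen with compound 2 is not confined to 2,3,4-trifluorophenyl: the limit of > 166000 nM in this assay, at which 2 of the 3 values shown sit.

From the compounds shown here alone, how far the true values of compound 2 and compound 3 lie from that limit remains open, as does whether the number for compound 1 needs both chlorine atoms or only one. Also open, going by these compounds, is how this read-out responds to a phenyl bearing a methoxy group or an amine at this place.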